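Fluoro to methyl in a three-compound series

The source may report more compounds than this note shows. Statements on the series, on what has been measured and on what is new or still open speak of the compounds shown alone.

Working notes on compound 1 (`COc1ccc(-c2c(Nc3ccc(C)cc3)c3ccc(OC)cc3oc2=O)cc1`), compound 2 (`COc1ccc(-c2c(Nc3ccc(F)cc3)c3ccc(O)cc3oc2=O)cc1`) and the unmeasured compound 3 (`COc1ccc(-c2c(Nc3ccc(C)cc3)c3ccc(O)cc3oc2=O)cc1`). In a functional assay on MCF7 cells (Homo sapiens) for antiproliferative activity, read by MTT assay, with a stated time of 48 h (on this read-out higher numbers stand for weaker inhibition and lower numbers for stronger inhibition), compound 2 gives 71500 nM and compound 1 gives 66900 nM, so the two numbers lie within the scatter of each other.

The step to compound 3 puts methyl in place of fluoro on an aromatic carbon, para to a large group, turning (4-fluorophenyl)amino into (4-methylphenyl)amino (methyl in place of fluoro on an aromatic carbon). Compound 3 thereby carries the same (4-methylphenyl)amino group as compound 1. Going by the values given here, compounds 1 and 2 differ in more than one place, so no measured single-place step shows the size of this change.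

In this assay no step beyond the scatter is expected, and no direction is favoured. This expectation rests only on the closeness of compound 1 at 66900 nM and compound 2 at 71500 nM. The expected step of a 1.1-fold lower number from compound 2 to compound 3 (0.02 log units; within the scatter) is therefore small. For compound 3 the estimated value is 68000 nM, with an expected range of 35000 nM to 125000 nM.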

Compound 3, half-maximal inhibitory concentration: 85500 nM
Compound 3: the middle estimate sits 1.3-fold (0.10 log units) below what was measured; the range from low to high includes it.
By their numbers in this assay, from the lowest: compounds 1, 2 and 3 (each within the scatter of the next).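

In this assay, methyl in place of fluoro on an aromatic carbon, para to a large group, can now be read as a single-place change: a 1.2-fold higher number from compound 2 to compound 3 (0.08 log units; within the scatter) stays within the scatter, so this exchange at this position leaves no measurable mark on the read-out. The second single-place comparison, hydrogen in place of methyl on an oxygen on an aromatic ring, gives a 1.3-fold higher number from compound 1 to compound 3 (0.11 log units; within the scatter) and also stays within the scatter, so the closeness of compound 1 and compound 2, which differ in more than one place, now breaks down into two separate steps, neither of them beyond the scatter. Nothing available explains why either exchange stays within the scatter.

On these data alone, whether an amine or a carboxylic acid on that same aromatic carbon would give a step beyond the scatter remains open, as does the effect of a longer chain on the oxygen. As far as these compounds go, it is also open whether these small steps would hold in a read-out other than this assay and on a core carrying different substituents elsewhere.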